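Fluoro for phenyl on compound 2: cytotoxicity outlook

A few compounds are considered here, and "the series" means these few. Any claim that something is new, unique, unknown or untested is made for them only; others in the source may bear on it.

Compound 2 `Cc1cc(C#N)cc(C)c1Oc1nc(Nc2ccc(C#N)cc2)ncc1-c1ccc(-c2ccccc2)cc1` sits at the top of the series in an ADME assay on MT4 cells (Homo sapiens) for cytotoxicity, read by MTT assay, with a stated time of 5 days (on this read-out higher numbers stand for lower toxicity in this test and lower numbers for higher toxicity in this test), with only a limit, > 253000 nM, no number; this is the limit of > 253000 nM in this assay, at which 1 of the 3 values shown sits. Compound 1 `Cc1cc(C#N)cc(C)c1Oc1nc(Nc2ccc(C#N)cc2)ncc1-c1ccc(N)cc1` gives 310 nM in this assay, and compound 3 `Cc1cc(C#N)cc(C)c1Oc1nc(Nc2ccc(C#N)cc2)ncc1-c1ccccc1` gives 31800 nM. Compound 4 `Cc1cc(C#N)cc(C)c1Oc1nc(Nc2ccc(C#N)cc2)ncc1-c1ccc(F)cc1` carries the change (fluoro in place of phenyl on an aromatic carbon). The step that bears on it most directly is an at least 7.9-fold lower number from compound 2 to compound 3 (0.90 log units; beyond the scatter); the larger 100-fold higher number from compound 1 to compound 3 (2.01 log units; beyond the scatter) shows the same position moving the number widely. A fluoro is nearer in size to hydrogen than to phenyl, so compound 4 is expected to land near compound 3, and the step of an at least 8.4-fold lower number from compound 2 to compound 4 (0.92 log units; beyond the scatter) is expected to be a lower number. Compound 4 is thus estimated at 30000 nM, within 8000 nM to 150000 nM.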

Compound 4, half-maximal cytotoxic concentration: 42700 nM
For compound 4 the middle estimate is 1.4-fold (0.15 log units) below the measured one; the range from low to high includes it.
By their numbers in this assay, from the lowest: compound 1; then compounds 3 and 4 (each within the scatter of the next). At a limit, above all of these: compound 2.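

In this assay, fluoro and hydrogen on this aromatic carbon cannot be told apart: a 1.3-fold higher number from compound 3 to compound 4 (0.13 log units; within the scatter). Fluoro stays well separated from both other groups, with phenyl giving an at least 5.9-fold lower number from compound 2 to compound 4 (0.77 log units; beyond the scatter) and amino giving a 140-fold higher number from compound 1 to compound 4 (2.14 log units; beyond the scatter), so the low number is not shared by this second small group. The phenyl comparison rests on a limit for compound 2: the limit of > 253000 nM in this assay, at which 1 of the 4 values shown sits.

Left open is whether a hydroxyl or a dimethylamino here would fall as low as amino. Also open, as far as these compounds go, is whether a methoxy would stay with fluoro and hydrogen, and whether a pyridyl would behave like phenyl.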